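A few compounds are considered here, and "the series" means these few. Any claim that something is new, unique, unknown or untested is made for them only; others in the source may bear on it.

Measured in a functional assay on A-431 cells (Homo sapiens) for cytotoxicity, read by MTT assay, with a stated time of 48 h; on this read-out higher numbers stand for weaker inhibition and lower numbers for stronger inhibition:
compound 1 `CCCCCCCCCCCCCCCCCCNC(=O)[C@@H](N)[C@@H](C)O` gives 21300 nM
compound 2 `CCCCCCCCCCCCCCCCCCNC(=O)[C@@H](NC(=O)c1nccc2ccccc12)[C@@H](C)O` gives 44100 nM

Compound 2 stands highest of the two numbers, compound 1 being the nearest. Among the compounds with values here, the one measured step, a 2.1-fold higher number from compound 1 to compound 2 (0.32 log units; beyond the scatter), shows that acylation of the amine raised the number modestly. Compound 3 `CCCCCCCCCCCCCCCCCCNC(=O)[C@@H](NC(=O)/C=C/c1ccccc1)[C@@H](C)O` keeps an acyl group on that nitrogen and differs from compound 2 only by 2-phenylethenyl in place of isoquinolin-1-yl on a carbonyl carbon. Within the data shown here, no measured step covers an exchange of one acyl group for another, so the size of that step is open; compound 3 is expected to stay near compound 2, with an estimated step of a 1.3-fold lower number from compound 2 to compound 3 (0.10 log units; within the scatter) in this assay. For compound 3 the estimate is 35000 nM, ranging from 12000 nM to 100000 nM.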

Compound 3, half-maximal inhibitory concentration: 177000 nM
Estimate against measurement, compound 3: 5.1-fold (0.70 log units) below; the measured number lies above the stated range.
By their numbers in this assay, from the lowest: compound 1; then compound 2; then compound 3.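

In this assay the result shows that the identity of the acyl group on this amine nitrogen counts, not only its presence: 2-phenylethenyl in place of isoquinolin-1-yl on the carbonyl carbon gives a 4.0-fold higher number from compound 2 to compound 3 (0.60 log units; beyond the scatter). Against the free amine, (2-phenylethenyl)carbonyl gives an 8.3-fold higher number from compound 1 to compound 3 (0.92 log units; beyond the scatter), so both acylated compounds read higher than compound 1. No evidence on the origin of these steps is available.

Open, as far as these compounds go, is how a 2-phenylethyl group, lacking the double bond, would read on that carbonyl carbon. From the compounds shown here alone, an acetyl or benzoyl group on the amine nitrogen also remains open.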